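From Compound 3 to Compound 4: a Halogen Pattern Change

The source may report more compounds than this note shows. Statements on the series, on what has been measured and on what is new or still open speak of the compounds shown alone.

Compound 1 `COc1ccc2[nH]c3c(c2c1)CCNC31CCN(Cc2ccc(Cl)cc2Cl)CC1`, compound 2 `COc1ccc2[nH]c3c(c2c1)CCNC31CCN(Cc2c(F)ccc(Cl)c2F)CC1` and compound 3 `COc1ccc2[nH]c3c(c2c1)CCNC31CCN(Cc2ccc(Br)cc2F)CC1` share one core and differ only in the group on a saturated chain carbon bound to an amine nitrogen in a ring. In an assay on FRT cells for positive allosteric modulation of Cystic fibrosis transmembrane conductance regulator variant N1303K (Homo sapiens), in the presence of a further agent that is not named here (a lower number here means that less compound is needed, a higher number that more compound is needed for the effect), compound 1 gives 1800 nM, compound 2 gives 1500 nM and compound 3 gives 1600 nM. Compound 3 stands within the scatter of both others, with a 1.1-fold lower number from compound 1 to compound 3 (0.05 log units; within the scatter) and a 1.1-fold higher number from compound 2 to compound 3 (0.03 log units; within the scatter). Compound 4 `COc1ccc2[nH]c3c(c2c1)CCNC31CCN(Cc2cc(F)c(F)c(F)c2)CC1` carries 3,4,5-trifluorophenyl in place of 4-bromo-2-fluorophenyl on a saturated chain carbon bound to an amine nitrogen in a ring. Within the data shown here, the steps that bear on this, a 1.2-fold lower number from compound 1 to compound 2 (0.08 log units; within the scatter) and a 1.1-fold higher number from compound 2 to compound 3 (0.03 log units; within the scatter), show that reshuffling halogens on this ring has not moved the number beyond the scatter. Compound 4 is therefore expected to stay close, a 1.1-fold higher number from compound 3 to compound 4 (0.03 log units; within the scatter), with an estimated 1700 nM and a range from 900 nM to 3400 nM.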

Compound 4, half-maximal effective concentration: 2600 nM
For compound 4 the middle estimate is 1.5-fold (0.18 log units) below the measured one; the range from low to high includes it.
By their numbers in this assay, from the lowest: compounds 2, 3, 1 and 4 (each within the scatter of the next).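

In this assay the move to 3,4,5-trifluorophenyl, with fluorine as the only halogen on the ring, gives a 1.6-fold higher number from compound 3 to compound 4 (0.21 log units; within the scatter) and, against the other two compounds, a 1.7-fold higher number from compound 2 to compound 4 (0.24 log units; within the scatter) and a 1.4-fold higher number from compound 1 to compound 4 (0.16 log units; within the scatter) so that all three steps stay within the scatter. This position on a saturated chain carbon bound to an amine nitrogen in a ring therefore tolerates the loss of bromine and chlorine without a change beyond the scatter. No evidence is available on what lies behind these numbers.

On these data alone, all four compounds carry a halogenated phenyl here, so it remains open whether a pyridine, a methoxyphenyl or a carboxylic acid at this place would move the number beyond the scatter.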